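The source may report more compounds than this note shows. Statements on the series, on what has been measured and on what is new or still open speak of the compounds shown alone.

Compound 1 `COc1cccc(-c2cccc(NC(=O)CCc3cccc4c3COB4O)c2)c1` gives 46000 nM in a functional assay on HCT-116 cells (Homo sapiens) for antiproliferative activity, read by MTT assay, with a stated time of 72 h; on this read-out higher numbers stand for weaker inhibition and lower numbers for stronger inhibition. Compound 2 `CC(=O)c1ccc(-c2cccc(NC(=O)CCc3cccc4c3COB4O)c2)cc1` gives 48000 nM in this assay, a step of a 1.0-fold higher number from compound 1 to compound 2 (0.02 log units; within the scatter) for the change (4-acetylphenyl in place of 3-methoxyphenyl on an aromatic carbon). Compound 3 `COc1cccc(-c2cccc(NC(=O)CCc3cccc4c3C(O)OC4)c2)c1` carries a different core; the difference between the two cores is not broken down here. In this assay compound 3 gives 49000 nM, within the scatter of both compound 1 and compound 2. Compound 4 `CC(=O)c1ccc(-c2cccc(NC(=O)CCc3cccc4c3C(O)OC4)c2)cc1` has not yet been measured in this assay; it differs from compound 3 by 4-acetylphenyl in place of 3-methoxyphenyl on an aromatic carbon, the same change as from compound 1 to compound 2, at the same place. The step is expected to be a 1.0-fold higher number from compound 3 to compound 4 (0.01 log units; within the scatter), about as small as the earlier one, because a 1.0-fold higher number from compound 1 to compound 2 (0.02 log units; within the scatter) stayed within the scatter. Compound 4 is therefore estimated at 50000 nM, expected between 25000 nM and 100000 nM.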

Compound 4, half-maximal inhibitory concentration: 18000 nM
Beside the measured number, compound 4's estimate is 2.8-fold (0.44 log units) above it; the measured number lies below the stated range.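

In this assay the change to 4-acetylphenyl does not carry over unchanged from one core to the other: the same change on two cores in this assay, a 1.0-fold higher number (0.02 log units; within the scatter) from compound 1 to compound 2 and a 2.7-fold lower number (0.43 log units; beyond the scatter) from compound 3 to compound 4, 2.8-fold (0.45 log units) apart, beyond the scatter of two such steps. The new step reads a 2.7-fold lower number from compound 3 to compound 4 (0.43 log units; beyond the scatter), and with 4-acetylphenyl held fixed the exchange of cores reads a 2.7-fold lower number from compound 2 to compound 4 (0.43 log units; beyond the scatter), so in these compounds the effect of the change depends on the core that carries it. This rests on a single pair on each of two cores, and it shows neither the reason for the gap nor whether any other group would behave the same way.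

Still open, going by these compounds, is whether an amine or a carboxylic acid in place of the 4-acetylphenyl group would also give steps that differ between the two cores. Also open, on these data alone, is how a longer chain to the amide carbonyl would affect either core.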